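The compounds below may be only part of what the source reports. "The series", "measured", "known", "first", "only" and "open" are said of these compounds alone.

Compound 1 `CCCCCC(CCO)n1cnc2c(Cl)ncnc21`: > 50000 nM, a limit of the assay
Compound 2 `CCCCCCC(CCO)n1cnc2c(Cl)ncnc21`: 11900 nM
Compound 3 `CCCCCCCCCC(CCO)n1cnc2c(Cl)ncnc21`: 890 nM

These results come from a functional assay on HCT-116 cells (Homo sapiens) for antiproliferative activity, read by MTT assay, with a stated time of 48 h; a higher number here means a weaker inhibitor, a lower number a stronger inhibitor. Compound 3 has the lowest number of the three, and its closest neighbour on the scale is reached by a 13-fold lower number from compound 2 to compound 3 (1.13 log units; beyond the scatter). The next structure, compound 4 `CCCCCCCCCC(CCN=[N+]=[N-])n1cnc2c(Cl)ncnc21`, keeps the rest of compound 3 but carries azido in place of hydroxy on a saturated chain carbon, three bonds along the chain from an aromatic nitrogen.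

The measured steps bear on this change only indirectly. All of them lengthen the alkyl chain: an at least 4.2-fold lower number from compound 1 to compound 2 (0.62 log units; beyond the scatter), an at least 56-fold lower number from compound 1 to compound 3 (1.74 log units; beyond the scatter) and a 13-fold lower number from compound 2 to compound 3 (1.13 log units; beyond the scatter). Those steps were sizeable, but none of them replaces the hydroxy group, so their size cannot simply be carried over. With the long chain of compound 3 retained, a small move toward weaker inhibition is expected, and the uncertainty is wide. The expected change is a 2.2-fold higher number from compound 3 to compound 4 (0.35 log units; beyond the scatter). For compound 4 the estimated value is 2000 nM, with an expected range of 400 nM to 9000 nM.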

Compound 4, half-maximal inhibitory concentration: 1040 nM
The estimate for compound 4 lay 1.9-fold (0.28 log units) above the measured number; measured number inside the range.
By their numbers in this assay, from the lowest: compounds 3 and 4 (each within the scatter of the next); then compound 2. At a limit, above all of these: compound 1.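

For the compounds shown here, until now only the alkyl chain had changed, so this is the first reading on the group at the other end of the molecule, on a saturated chain carbon, three bonds along the chain from an aromatic nitrogen. In this assay, replacing hydroxy with azido gives a 1.2-fold higher number from compound 3 to compound 4 (0.07 log units; within the scatter), so the two compounds cannot be told apart. With the long chain of compound 3 kept, the hydrogen-bond donor of the hydroxy group is therefore not required to hold this level of activity, since azido has none.

As far as these compounds go, whether an amine or a carboxylic acid at this place would also match compound 3 stays open, as does whether azido would match hydroxy on the shorter chain of compound 2. Nothing shown gives a reason for the match between compound 3 and compound 4.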